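Replacing the Side Group of Compound 3

This account rests on a few compounds, and the source may have more. Where it says the series, first, only, none or still open, it means among the compounds named here.

Measured in an ADME assay on S9 fraction from liver (Rattus norvegicus) for metabolic stability, with a stated time of 1 h; on this read-out lower numbers stand for a less stable compound and higher numbers for a more stable compound:
- compound 1 `N#Cc1cnc(NCc2cnccc2C(F)(F)F)cc1N[C@H]1CC[C@H](O)CC1`: 25%
- compound 2 `N#Cc1cnc(NCc2cnccc2C(F)(F)F)cc1NC[C@H]1CC[C@H](O)CC1`: 6%
- compound 3 `CO[C@H]1CC[C@@H](CNc2cc(NCc3cnccc3C(F)(F)F)ncc2C#N)CC1`: 2%

Compound 3 and compound 2 lie within the usual scatter of each other, and compound 1 stands clearly higher than both. The next molecule, compound 4 `N#Cc1cnc(NCc2cnccc2C(F)(F)F)cc1NC1CCOCC1`, has oxan-4-yl in place of (4-methoxycyclohexyl)methyl on a nitrogen on an aromatic ring.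

Two measured steps offer the closest guide: a number 19 percentage points lower from compound 1 to compound 2 (beyond the scatter) and a number 23 percentage points lower from compound 1 to compound 3 (beyond the scatter). Both lead away from 4-hydroxycyclohexyl to a cyclohexylmethyl group, and compound 4 has no such group. The step of a number 4 percentage points lower from compound 2 to compound 3 (within the scatter) suggests that the methoxy and hydroxy forms can be treated alike here. For the measured compounds named here, a rise of similar size, beyond the scatter, therefore seems likely, although no measured compound carries oxan-4-yl. The expected change is a number 26 percentage points higher from compound 3 to compound 4 (beyond the scatter). In this assay, the estimate for compound 4 is 28%, within an expected range from 10% to 55%.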

Compound 4, percent of the compound remaining: 17%
Beside the measured number, compound 4's estimate is 11 percentage points above it; low and high end bracket the measured number.
By their numbers in this assay, from the lowest: compounds 3 and 2 (each within the scatter of the next); then compounds 4 and 1 (each within the scatter of the next).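

In this assay, oxan-4-yl on a nitrogen on an aromatic ring gives a number 15 percentage points higher from compound 3 to compound 4 (beyond the scatter) and a number 11 percentage points higher from compound 2 to compound 4 (beyond the scatter), so this group stands clearly above both cyclohexylmethyl groups, whether they end in methoxy or hydroxy. Against 4-hydroxycyclohexyl the change does not separate, with a number 8 percentage points lower from compound 1 to compound 4 (within the scatter), so among these four compounds the two ring groups without the extra methyl link, in compound 1 and compound 4, both stand clear of the two groups that have it. No measurement shown here accounts for this pattern.

Going from compound 3 to compound 4 alters the ring and the methyl link together, so their separate shares remain open. An oxan-4-ylmethyl group would isolate the link, and a piperidin-4-yl group would show whether a ring nitrogen reads like the ring oxygen.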